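The source may report more compounds than this note shows. Statements on the series, on what has been measured and on what is new or still open speak of the compounds shown alone.

Working notes on the series.

Compound 1 `CCNC(=O)N1CCN(C(=S)SCc2cn(Cc3ccc(C)cc3)nn2)CC1` and compound 2 `Cc1ccc(Cn2cc(CSC(=S)N3CCN(C(=O)NC(C)C)CC3)nn2)cc1` share one core and differ in a single place: methyl in place of hydrogen on a saturated chain carbon bound to an amide-type nitrogen and a saturated chain carbon. In a functional assay on SMMC-7721 cells (Homo sapiens) for cytotoxicity, read by MTT assay, with a stated time of 72 h (a higher number here means a weaker inhibitor, a lower number a stronger inhibitor), compound 1 gives > 128000 nM, a limit of the assay. In this assay compound 2 gives > 128000 nM, likewise a limit. The step that the two limits leave unreadable from compound 1 to compound 2 therefore cannot be read in either direction; both values simply sit at the limit of > 128000 nM in this assay, at which 3 of the 3 values shown sit.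

Compound 3 `CCNC(=O)N1CCN(C(=S)SCc2cn(Cc3cc(OC)c(OC)c(OC)c3)nn2)CC1` carries a different core from compound 1; the difference between the two cores is not broken down here. In this assay compound 3 gives > 128000 nM, again a limit. Going by the values given here, with all three measured compounds at the same limit, the series so far shows no readable activity and no readable step.

Compound 4 `COc1cc(Cn2cc(CSC(=S)N3CCN(C(=O)NC(C)C)CC3)nn2)cc(OC)c1OC` has not yet been measured in this assay. It differs from compound 3 by methyl in place of hydrogen on a saturated chain carbon bound to an amide-type nitrogen and a saturated chain carbon, which is the same change as that between compound 1 and compound 2, at the same kind of place. For compound 4 the expectation rests on compound 3, whose value > 128000 nM is a limit, and on compound 1 and compound 2, whose shared change left the step that the two limits leave unreadable from compound 1 to compound 2 unreadable. The expected step that the limit leaves unreadable from compound 3 to compound 4 is thus one that is unlikely to surface above the limit. Compound 4 is expected at about 150000 nM, within 100000 nM to 300000 nM, most probably reported as a limit rather than a number.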

Compound 4, half-maximal inhibitory concentration: > 128000 nM
Compound 4 ended at the assay's limit; the forecaster's own chance of this, stated with the estimate: 85%; the middle value is on the limit's open side.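

In this assay compound 4 gives > 128000 nM, a limit and not a number. No step can be read from compound 3 to compound 4, and the series still shows no readable activity: the limit of > 128000 nM in this assay, at which 4 of the 4 values shown sit.

The compounds shown leave open whether ethylcarbamoyl to isopropylcarbamoyl has any effect on potency in this assay, and which changes to the shared core would bring a value inside the assay's range.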